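Moving the hydroxyl: from compound 2 to compound 4

The compounds below may be only part of what the source reports. "The series", "measured", "known", "first", "only" and "open" are said of these compounds alone.

Compound 1 `Oc1ccc(-c2cc(-c3cccc(Cl)c3)nc(-c3cccs3)c2)cc1`: 52.4%
Compound 2 `Oc1cccc(-c2cc(-c3cccc(Cl)c3)nc(-c3ccco3)c2)c1`: 5.5%
Compound 3 `Oc1cccc(-c2cc(-c3cccc(Cl)c3)nc(-c3cccs3)c2)c1`: 7.6%

These three were tested in an assay on isolated protein for inhibition of DNA topoisomerase 1 (Homo sapiens), with a stated time of 30 min, tested at 100 uM; on this read-out lower numbers stand for a weaker effect and higher numbers for a stronger effect at the one concentration tested. Compound 2 sits lowest of the three; compound 3 lies within the scatter of it, while compound 1 stands well apart, beyond the scatter.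

Compound 4 `Oc1ccc(-c2cc(-c3cccc(Cl)c3)nc(-c3ccco3)c2)cc1` has not yet been measured. It differs from compound 2 in one place: 4-hydroxyphenyl in place of 3-hydroxyphenyl on an aromatic carbon. The same change, run in reverse, is the step from compound 1 to compound 3, which gave a number 44.8 percentage points lower from compound 1 to compound 3 (beyond the scatter). The other measured step, a number 2.1 percentage points higher from compound 2 to compound 3 (within the scatter), shows that swapping furan-2-yl for thiophen-2-yl hardly matters here, so the hydroxyl shift should carry over to the furan-containing pair. A large rise in this assay is therefore expected for compound 4, a number 42.5 percentage points higher from compound 2 to compound 4 (beyond the scatter). Compound 4 is estimated at 48%, within a range from 25% to 65%.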

Compound 4, a percentage reported as inhibition, at one concentration (the size of the read-out at that concentration, not a potency): 25.5%
Compound 4: the middle estimate sits 22.5 percentage points above what was measured, and the stated range covers the measured number.
By their numbers in this assay, from the lowest: compounds 2 and 3 (each within the scatter of the next); then compound 4; then compound 1.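

With furan-2-yl on the core, the hydroxyl shift gives a number 20 percentage points higher from compound 2 to compound 4 (beyond the scatter) and so keeps its direction but not its size: the same change on two cores in this assay, a number 44.8 percentage points lower (beyond the scatter) from compound 1 to compound 3 and a number 20 percentage points lower (beyond the scatter) from compound 4 to compound 2, 24.8 percentage points apart, beyond the scatter of two such steps. Furan-2-yl in place of thiophen-2-yl gives a number 26.9 percentage points lower from compound 1 to compound 4 (beyond the scatter) when 4-hydroxyphenyl is present, so this swap does not leave the number unchanged on every core: the same change on two cores in this assay, a number 2.1 percentage points higher (within the scatter) from compound 2 to compound 3 and a number 26.9 percentage points higher (beyond the scatter) from compound 4 to compound 1, 24.8 percentage points apart, beyond the scatter of two such steps. The two changes therefore do not simply add up.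

The compounds shown leave open whether the hydroxyl itself matters at this position. A methoxy group or an amine on the same phenyl ring could test that.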